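Replacing the naphthyl amide in an antiproliferative thiophene series

The source may report more compounds than this note shows. Statements on the series, on what has been measured and on what is new or still open speak of the compounds shown alone.

Measured compounds: compound 1 `COC(=O)c1scc(-c2ccc(NC(=O)c3cc(I)ccc3F)cc2)c1OC` gives 22500 nM in a functional assay on MCF7 cells (Homo sapiens) for antiproliferative activity, read by MTT assay, with a stated time of 24 h; a higher number here means a weaker inhibitor, a lower number a stronger inhibitor; compound 2 `COC(=O)c1scc(-c2ccc(NC(=O)c3ccc4ccccc4c3)cc2)c1OC` gives 90 nM; compound 3 `COC(=O)c1scc(-c2ccc(NC(=O)c3cccc(OC(F)(F)F)c3)cc2)c1OC` gives 2220 nM.

Compound 2 stands lowest of the three numbers; compound 3 sits well above it and compound 1 further still. For the measured compounds named here, the one single-point step that is known, a 250-fold lower number from compound 1 to compound 2 (2.40 log units; beyond the scatter), shows how much the group on the carbonyl carbon can matter. Compound 4 `COC(=O)c1scc(-c2ccc(NC(=O)c3ccc(C(F)(F)F)cc3)cc2)c1OC` differs from compound 2 by 4-(trifluoromethyl)phenyl in place of naphthalen-2-yl on a carbonyl carbon. The two single-ring analogues, compound 1 and compound 3, both return far higher numbers than compound 2, so a step upward beyond the scatter is expected for compound 4, a 17-fold higher number from compound 2 to compound 4 (1.22 log units; beyond the scatter). Compound 4 is therefore estimated at 1500 nM, within 300 nM to 8000 nM.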

Compound 4, half-maximal inhibitory concentration: 24600 nM
Beside the measured number, compound 4's estimate is 16-fold (1.21 log units) below it, outside the stated range (above it).
By their numbers in this assay, from the lowest: compound 2; then compound 3; then compounds 1 and 4 (each within the scatter of the next).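

On the carbonyl carbon, the 4-(trifluoromethyl)phenyl group gives up the low number of the naphthalen-2-yl group: this assay shows a 270-fold higher number from compound 2 to compound 4 (2.44 log units; beyond the scatter). Exchanging one substituted phenyl group for another shows a 1.1-fold higher number from compound 1 to compound 4 (0.04 log units; within the scatter), so this change and the 2-fluoro-5-iodophenyl group leave the same distance from compound 2. Compound 3, at 2220 nM, goes against any rule that single-ring groups all land there.

Nothing shown accounts for these numbers. From the compounds shown here alone, whether an amine or a methoxy group on the naphthalen-2-yl group would keep the low number of compound 2 remains open.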